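This account rests on a few compounds, and the source may have more. Where it says the series, first, only, none or still open, it means among the compounds named here.

Measured so far in a functional assay on MCF7 cells (Homo sapiens) for inhibition; a lower number here means a stronger inhibitor, a higher number a weaker inhibitor:
- compound 1 `CC/C(=C(/c1ccc(/C=C/C(=O)O)cc1)c1cc2ccccc2[nH]1)c1ccccc1C(F)(F)F` gives 8 nM
- compound 2 `CC/C(=C(/c1ccc(/C=C/C(=O)O)cc1)c1cc2ccccc2[nH]1)c1ccc(C(F)(F)F)cc1` gives 139 nM
- compound 3 `CC/C(=C(/c1ccc(/C=C/C(=O)O)cc1)c1cc2ccccc2[nH]1)c1cccc(Cl)c1Cl` gives 898 nM

Compound 3 stands highest of the three numbers in this assay. Its gaps to the others, a 110-fold higher number from compound 1 to compound 3 (2.05 log units; beyond the scatter) and a 6.5-fold higher number from compound 2 to compound 3 (0.81 log units; beyond the scatter), both lie beyond the scatter, so compound 3 is the weakest inhibitor of the set.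

Next comes compound 4 `CC/C(=C(/c1ccc(/C=C/C(=O)O)cc1)c1cc2ccccc2[nH]1)c1cc(Cl)ccc1Cl`. The change is 2,5-dichlorophenyl in place of 2,3-dichlorophenyl on a double-bonded chain carbon bound to a double-bonded chain carbon and a saturated chain carbon. Within the data shown here, no measured step moves a chlorine from one position to another on this ring; what the measured steps show is only that the substitution pattern on this ring matters strongly, as in a 17-fold higher number from compound 1 to compound 2 (1.24 log units; beyond the scatter) and a 110-fold higher number from compound 1 to compound 3 (2.05 log units; beyond the scatter). Compound 3 and compound 4 both keep a 2-chloro substituent and differ only in where the second chlorine sits, a move none of those steps models, so the direction of the step in this assay is open. A step of modest size, in either direction, is expected, with the wider uncertainty toward stronger inhibition given how far compound 3 sits above compound 1.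

Compound 4 is therefore estimated at 400 nM in this assay, with a range of 80 nM to 2000 nM. That estimate means a step of a 2.2-fold lower number from compound 3 to compound 4 (0.35 log units; beyond the scatter) is expected.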

Compound 4, half-maximal inhibitory concentration: 71 nM
Compound 4: middle estimate off by 5.6-fold (0.75 log units), on the high side, and the stated range ends above it.
By their numbers in this assay, from the lowest: compound 1; then compounds 4 and 2 (each within the scatter of the next); then compound 3.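

In this assay this position responds strongly to where the second chlorine sits, even with the atom count unchanged (a 13-fold lower number from compound 3 to compound 4 (1.10 log units; beyond the scatter)), so 2,5-dichlorophenyl and 2,3-dichlorophenyl cannot be treated as equivalent on the double-bonded chain carbon. The 2,5-dichlorophenyl group is not separated from 4-(trifluoromethyl)phenyl (a 2.0-fold lower number from compound 2 to compound 4 (0.29 log units; within the scatter)), while 2-(trifluoromethyl)phenyl keeps a clear lead over it (an 8.9-fold higher number from compound 1 to compound 4 (0.95 log units; beyond the scatter)), leaving compound 1 the strongest inhibitor of the four. No measured evidence on the compounds accounts for these differences.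

The compounds shown leave open how much of the activity of compound 4 depends on each chlorine, which a single chlorine on this ring would help to separate. Also open, as far as these compounds go, is whether a nitrile or a methoxy group in place of either chlorine, or a second trifluoromethyl group on the ring of compound 1, would keep or improve the activity seen with these substituents.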